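The compounds below may be only part of what the source reports. "The series", "measured", "known", "first", "only" and "open" are said of these compounds alone.

Measured compounds:
- compound 1 `COc1cc(Cl)cc(-c2nn(-c3cccc(NC(=O)Nc4ccc(Cl)c(C(F)(F)F)c4)c3)cc2-c2ccncc2)c1`: -13%
- compound 2 `COc1cc(Cl)cc(-c2nn(-c3cccc(NC(=O)Nc4cccc(C(F)(F)F)c4)c3)cc2-c2ccncc2)c1`: -9.92%

In a functional assay on PC-3 cells (Homo sapiens) for inhibition, read by sulforhodamine B assay, with a stated time of 48 h, tested at 10 uM (a lower number here means a stronger effect, a higher number a weaker effect of the compound at the concentration tested), compound 1 gives -13% and compound 2 gives -9.92%. Both numbers lie close to zero, so neither compound shows a clear effect at the concentration tested. For the measured compounds named here, compound 2 stands at the upper end of the two numbers, but the only measured step, a number 3.1 percentage points higher from compound 1 to compound 2 (within the scatter), is within the scatter, so the two compounds cannot be told apart on these data.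

Compound 3 `COc1cc(Cl)cc(-c2nn(-c3cccc(NC(=O)c4cccc(C(F)(F)F)c4)c3)cc2-c2ccncc2)c1` differs from compound 2 by 3-(trifluoromethyl)phenyl in place of (3-(trifluoromethyl)phenyl)amino on a carbonyl carbon. Going by the values given here, no measured step bears on this kind of change: the one step available swaps a chloro for a hydrogen on an aromatic carbon and is itself within the scatter. There is therefore no measured basis for expecting a step in either direction, and the expected step of a number 4.9 percentage points higher from compound 2 to compound 3 (within the scatter) is no step beyond the scatter. Compound 3 is estimated at -5%, with a range from -30% to 20%.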

Compound 3, a percentage reported as activity, at one concentration (the size of the read-out at that concentration, not a potency): 23.1%
Compound 3: the middle estimate sits 28.1 percentage points below what was measured; the whole stated range lies below it.
By their numbers in this assay, from the lowest: compounds 1 and 2 (each within the scatter of the next); then compound 3.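

In this assay the carbonyl carbon proves to be a place where a change registers, unlike the swap of chloro for hydrogen on the outer ring: placing the 3-(trifluoromethyl)phenyl directly on the carbonyl carbon, with the amino nitrogen gone, gives a number 33 percentage points higher from compound 2 to compound 3 (beyond the scatter) and moves the number toward a weaker effect. The comparison with the chlorinated compound points the same way, with a number 36.1 percentage points higher from compound 1 to compound 3 (beyond the scatter), although that change also removes the chloro. What leaves with the nitrogen is a single hydrogen-bond donor, but nothing available ties the step to that donor or explains it in any other way.

The amino nitrogen and its hydrogen remain inseparable here, and a methylamino group or a methylene on the carbonyl carbon would show which of the two the number follows. As far as these compounds go, it also remains open whether a chloro on the outer ring of compound 3 would matter, given that the same swap on the amino-linked pair stayed within the scatter.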